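The source may report more compounds than this note shows. Statements on the series, on what has been measured and on what is new or still open speak of the compounds shown alone.

Measured so far:
- compound 1 `CCOC(=O)CCCCCOc1cccc(CN(C(=O)c2ccc(-c3ccc4ccccc4c3)cc2)C(C)C)c1` — an ADME assay on HepG2 cells (Homo sapiens) for cytotoxicity, read by CellTiter-Glo and resazurin assay, with a stated time of 72 h; on this read-out higher numbers stand for an effect only at larger amounts of compound and lower numbers for an effect already at smaller amounts: > 26000 nM, which is a limit of the assay and not a number.
- compound 2 `CCOC(=O)CCCCCOc1cccc(CN(C(=O)c2ccc(-c3ccc(C(C)=O)s3)cc2)C(C)C)c1` — this assay: > 26000 nM, again a limit of the assay and not a number.

For the measured compounds named here, compound 2 therefore stands only at a limit in this assay, and the one other value shown is a limit as well; both entries sit at the limit of > 26000 nM in this assay, at which 2 of the 2 values shown sit. Going by the values given here, the single recorded step, a step that the two limits leave unreadable from compound 1 to compound 2, is consequently unreadable, and its size cannot be taken from the two limits.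

Compound 3 `CCOC(=O)CCCCCOc1cccc(CN(C(=O)c2ccc(-c3cccc(OC)c3)cc2)C(C)C)c1` differs from compound 2 in one place: 3-methoxyphenyl in place of 5-acetylthiophen-2-yl on an aromatic carbon. Among the compounds with values here, no measured step in this assay bears readably on this change, since the only step available, from a naphthalen-2-yl to a 5-acetylthiophen-2-yl group, gave nothing more than two limits. On that basis no step beyond the scatter is expected in this assay from compound 2 to compound 3, and the result is expected to be reported again as a limit rather than a number.

Compound 3 is estimated at 30000 nM in this assay, within 15000 nM to 90000 nM, the expected step being a step that the limit leaves unreadable from compound 2 to compound 3.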

Compound 3, half-maximal effective concentration: > 21000 nM
Compound 3: no number, only a limit; the forecaster's own chance of this, stated with the estimate: 85%; the middle value lies beyond the limit too.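

In this assay compound 3 gives > 21000 nM, a limit of the assay and not a number. For the compounds shown here, no step among compound 1, compound 2 and compound 3 can be read, as all three entries are limits. Left open is whether naphthalen-2-yl, 5-acetylthiophen-2-yl and 3-methoxyphenyl differ at all in this assay, and at what concentration any of these compounds reaches its half-maximal effect.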